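A few compounds are considered here, and "the series" means these few. Any claim that something is new, unique, unknown or untested is made for them only; others in the source may bear on it.

Measured so far in an ADME assay on PBMC cells (Homo sapiens) for cytotoxicity, read by MTT assay; a lower number here means a stronger inhibitor, a higher number a weaker inhibitor:
compound 1 `O=C(N/N=C/N1CCN(c2cc3c(cc2F)c(=O)c(C(=O)O)cn3C2CC2)CC1)c1ccc(C(F)(F)F)cc1`: 347000 nM
compound 2 `O=C(N/N=C/N1CCN(c2cc3c(cc2F)c(=O)c(C(=O)O)cn3C2CC2)CC1)c1ccc(F)cc1`: a limit only, > 763000 nM
compound 3 `CCn1cc(C(=O)O)c(=O)c2cc(F)c(N3CCN(/C=N/NC(=O)c4ccc(C(F)(F)F)cc4)CC3)cc21`: 262000 nM

Compound 3 gives the lowest of the two numbers; the nearest number lies within the scatter, a 1.3-fold lower number from compound 1 to compound 3 (0.12 log units; within the scatter). Compound 4 `CCn1cc(C(=O)O)c(=O)c2cc(F)c(N3CCN(/C=N/NC(=O)c4ccc(F)cc4)CC3)cc21` is not yet measured. It differs from compound 3 as fluoro in place of trifluoromethyl on an aromatic carbon. The same change has been measured once in this series, giving an at least 2.1-fold higher number from compound 1 to compound 2 (0.34 log units; beyond the scatter). The step to compound 4 is therefore expected to go the same way and to be of at least similar size, a 2.3-fold higher number from compound 3 to compound 4 (0.36 log units; beyond the scatter). Compound 4 is expected at 600000 nM, within 300000 nM to 1200000 nM. Given (the limit of > 763000 nM in this assay, at which 1 of the 3 values shown sits), compound 4 may again return only a limit rather than a number.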

Compound 4, half-maximal inhibitory concentration: > 331000 nM
Compound 4: a limit, no number; the forecaster's own chance of this, stated with the estimate: 50%; the middle value does not contradict the limit.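

In this assay, the change from 4-(trifluoromethyl)phenyl to 4-fluorophenyl now has a second reading, on another core: an at least 1.2-fold higher number from compound 3 to compound 4 (0.10 log units; that floor lies within the scatter). Compound 4 gives only a limit, > 331000 nM. The two readings do not conflict, but their sizes cannot be ranked: the same change on two cores in this assay, an at least 2.1-fold higher number (0.34 log units; beyond the scatter) from compound 1 to compound 2 and an at least 1.2-fold higher number (0.10 log units; that floor lies within the scatter) from compound 3 to compound 4; the limit leaves it open whether they differ

The step from compound 2 to compound 4 cannot be read, so ethyl against cyclopropyl stays unresolved for the 4-fluorophenyl compounds. From the compounds shown here alone, what an amine or a carboxylic acid in place of fluoro would give also stays open.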